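Trading a Cyclopropyl for a Difluoroethyl on the Core

The source may report more compounds than this note shows. Statements on the series, on what has been measured and on what is new or still open speak of the compounds shown alone.

Measured so far:
Compound 1, `Cc1cc(Nc2ccc(S(F)(F)(F)(F)F)cc2)n2nc(C3CC3)nc2n1`, gives 97.7% in an ADME assay on a cell-free system (plasma, Homo sapiens) for protein binding.
Compound 2, `Cc1cc(Nc2ccc(C(F)(F)F)cc2)n2nc(C3CC3)nc2n1`, gives 92.8%.
Compound 3, `CCc1nc2nc(C)cc(Nc3ccc(C(F)(F)F)cc3)n2n1`, gives 87.5%.

Among these three, compound 1 has the lowest unbound fraction. Its nearest neighbour is compound 2, reached by a 3.1-fold higher unbound fraction from compound 1 to compound 2 (0.50 log units; beyond the scatter), a change at the aryl group rather than at the core. The step from compound 2 to compound 3 was a 1.7-fold higher unbound fraction from compound 2 to compound 3 (0.24 log units; within the scatter); this change is at the same place on the core that is altered below.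

Compound 4, `Cc1cc(Nc2ccc(S(F)(F)(F)(F)F)cc2)n2nc(C(C)(F)F)nc2n1`, has not yet been measured. It differs from compound 1 by 1,1-difluoroethyl in place of cyclopropyl on an aromatic carbon.

The step from compound 2 to compound 3 is the one that bears on this change, since it too swaps the cyclopropyl for an open chain at the same place; it was small and within the scatter. The aryl group of compound 4 is unchanged from compound 1, so the large step from compound 1 to compound 2 does not apply. The expectation is therefore a small step, if any, in this assay, in the direction of a slightly higher unbound fraction, that is, a 1.4-fold higher unbound fraction from compound 1 to compound 4 (0.14 log units; within the scatter) is expected. Compound 4 is estimated at 96.8%, with a range from 94% to 98.7%.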

Compound 4, plasma protein binding: 97.4%
Compound 4: the middle estimate sits 1.2-fold (0.09 log units) (unbound fraction) above what was measured; measured number inside the range.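

In this assay the step is a 1.1-fold higher unbound fraction from compound 1 to compound 4 (0.05 log units; within the scatter) and so does not separate the two compounds, even though an open 1,1-difluoroethyl group with two fluorine atoms has replaced the three-membered cyclopropyl ring. Earlier, the only change shown at this position was ethyl in place of cyclopropyl on compounds with the aryl group of compound 2, and that step, a 1.7-fold higher unbound fraction from compound 2 to compound 3 (0.24 log units; within the scatter), also stayed within the scatter; the new result adds a second open-chain group and a second aryl group, that of compound 1, with the same outcome. No measurement is available that would explain this result.

From the compounds shown here alone, it remains open whether a quite different group on this aromatic carbon, such as an amine, a carboxylic acid or a longer chain, would move the unbound fraction beyond the scatter. The compounds shown also leave open how 1,1-difluoroethyl would behave with the aryl group of compound 2, since it appears here only with the aryl group of compound 1.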